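The compounds below may be only part of what the source reports. "The series", "measured", "known", "first", "only" and "open" are said of these compounds alone.

Going by the values given here, compound 1 `COc1ccc(-c2cc3nccc(-c4cc(OC)c(OC)c(OC)c4)n3n2)cc1N` gives 283 nM in a functional assay on HeLa cells (Homo sapiens) for inhibition, read by CCK-8 assay, with a stated time of 48 h (a lower number here means a stronger inhibitor, a higher number a weaker inhibitor), the highest of the two numbers measured so far; compound 2 `COc1cc(-c2ccnc3cc(-c4ccc(C)cc4)nn23)cc(OC)c1OC` gives 21 nM. Compound 3 `COc1cc(-c2ccnc3cc(-c4ccc(N(C)C)cc4)nn23)cc(OC)c1OC` differs from compound 1 by 4-(dimethylamino)phenyl in place of 3-amino-4-methoxyphenyl on an aromatic carbon. Among the compounds with values here, the one measured step that bears on this change, a 13-fold lower number from compound 1 to compound 2 (1.13 log units; beyond the scatter), likewise replaced the 3-amino-4-methoxyphenyl with a differently substituted phenyl and was large. A step of similar direction and size is therefore expected here, a 9.4-fold lower number from compound 1 to compound 3 (0.97 log units; beyond the scatter). Compound 3 is estimated at 30 nM, with a likely range from 8 nM to 120 nM.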

Compound 3, half-maximal inhibitory concentration: 378 nM
Compound 3: middle estimate off by 13-fold (1.10 log units), on the low side, outside the stated range (above it).
By their numbers in this assay, from the lowest: compound 2; then compounds 1 and 3 (each within the scatter of the next).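

In this assay, leaving the 3-amino-4-methoxyphenyl is not enough on its own to give a stronger inhibitor: the new group gives a 1.3-fold higher number from compound 1 to compound 3 (0.13 log units; within the scatter). What matters here is the substituent on the phenyl, as dimethylamino in place of methyl gives an 18-fold higher number from compound 2 to compound 3 (1.26 log units; beyond the scatter). Nothing measured here explains this difference. Still open, from the compounds shown here alone, is how a 4-ethylphenyl or 4-chlorophenyl would compare with compound 2 and compound 3. So is whether a 4-aminophenyl would behave like the 4-(dimethylamino)phenyl.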